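A rearranged phenyl group on a sulfonamide nitrogen

The source may report more compounds than this note shows. Statements on the series, on what has been measured and on what is new or still open speak of the compounds shown alone.

Measured so far in a functional assay on cells (leukaemia cell line, Homo sapiens) for inhibition, read by sulforhodamine B assay, with a stated time of 48 h; on this read-out higher numbers stand for weaker inhibition of growth and lower numbers for stronger inhibition of growth
- Compound 1 `Cc1cc(NS(=O)(=O)c2ccc(-c3cnc(C4CC4)o3)cc2)ccc1Cl` gives 33400 nM
- Compound 2 `COc1cc(NS(=O)(=O)c2ccc(-c3cnc(C4CC4)o3)cc2)ccc1F` gives 75700 nM
- Compound 3 `Cc1ccc(Cl)c(NS(=O)(=O)c2ccc(-c3cnc(C4CC4)o3)cc2)c1` gives 52800 nM

Compound 3 lies within the usual scatter of both other compounds, so its number cannot be ranked against either of them. The next compound, compound 4 `Cc1cc(Cl)cc(NS(=O)(=O)c2ccc(-c3cnc(C4CC4)o3)cc2)c1`, has 3-chloro-5-methylphenyl in place of 2-chloro-5-methylphenyl on a sulfonamide nitrogen. The two groups have the same atoms, joined differently.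

The closest measured precedent is another rearrangement of the same atoms, a 1.6-fold higher number from compound 1 to compound 3 (0.20 log units; within the scatter), and it stayed within the scatter. Within the data shown here, the only step beyond the scatter, a 2.3-fold higher number from compound 1 to compound 2 (0.36 log units; beyond the scatter), was modest and exchanged different atoms. No step beyond the scatter, in either direction, is therefore expected in this assay. The expected step is a 1.1-fold lower number from compound 3 to compound 4 (0.04 log units; within the scatter). For compound 4 the estimated value is 48000 nM, with an expected range from 24000 nM to 90000 nM.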

Compound 4, concentration for total growth inhibition: 7040 nM
Compound 4: middle estimate off by 6.8-fold (0.83 log units), on the high side; the whole stated range lies above it.
By their numbers in this assay, from the lowest: compound 4; then compounds 1, 3 and 2 (each within the scatter of the next, the first and the last beyond it).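

In this assay, moving the chlorine on the phenyl group with no atom gained or lost gives a 7.5-fold lower number from compound 3 to compound 4 (0.88 log units; beyond the scatter), so the group on a sulfonamide nitrogen is sensitive to how its atoms are arranged, not only to which atoms it carries. Compound 4 also stands apart from the other two compounds, with an 11-fold lower number from compound 2 to compound 4 (1.03 log units; beyond the scatter) and a 4.7-fold lower number from compound 1 to compound 4 (0.68 log units; beyond the scatter); all three steps lie beyond the scatter, which makes compound 4 the strongest growth inhibitor of the four. Nothing shown gives a reason for this difference.

The compounds shown leave open whether both the chlorine and the methyl of compound 4 are needed, and what a trifluoromethyl group or an amine would give in place of that chlorine. Also open, going by these compounds, is whether the same order of compounds would hold in a different cell line.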